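Cinnamoyl-linked sugar analogues: removing the hydroxymethyl arm

The compounds below may be only part of what the source reports. "The series", "measured", "known", "first", "only" and "open" are said of these compounds alone.

Measured so far in an assay on isolated protein for inhibition of lysosomal alpha-glucosidase (Rattus norvegicus), tested at 100 uM; a lower number here means less inhibition, a higher number more inhibition at the concentration tested (going by the name of the read-out):
compound 1 `O=C(/C=C/c1ccccc1)C[C@@H]1O[C@H](CO)[C@@H](O[C@@H]2O[C@H](CO)[C@@H](O)[C@H](O)[C@H]2O)[C@H](O)[C@H]1O` gives -24.6%
compound 2 `CCOC(=O)C(C(=O)OCC)C(CC(=O)C[C@@H]1O[C@H](CO)[C@@H](O)[C@H](O)[C@H]1O)c1ccc(Cl)cc1` gives -10%
compound 3 `O=C(/C=C/c1ccc(Cl)cc1)C[C@@H]1O[C@H](CO)[C@@H](O)[C@H](O)[C@H]1O` gives -5.97%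

Compound 3 holds the highest of the three numbers in this assay, but compound 2 lies within the scatter of it; only compound 1 sits beyond the scatter below compound 3. Among the compounds with values here, all three numbers are negative, so none of the measured compounds shows inhibition at the tested concentration.

Compound 4 `O=C(/C=C/c1ccc(Cl)cc1)C[C@@H]1OC[C@@H](O)[C@H](O)[C@H]1O` is not yet measured. It differs from compound 3 by hydrogen in place of hydroxymethyl on a saturated ring carbon. Within the data shown here, with no step between measured compounds available, and no inhibition seen anywhere, no step beyond the scatter is expected in this assay in either direction. For compound 4 the estimate is -5%, within -25% to 15%, a step of a number 1 percentage points higher from compound 3 to compound 4 (within the scatter) that is expected to stay inside the scatter.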

Compound 4, a percentage reported as inhibition, at one concentration (the size of the read-out at that concentration, not a potency): -8.3%
Compound 4: middle estimate off by 3.3 percentage points, on the high side, within the range that was stated.
By their numbers in this assay, from the lowest: compound 1; then compounds 2, 4 and 3 (each within the scatter of the next).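

In this assay, hydrogen in place of hydroxymethyl on the saturated ring carbon next to the ring oxygen gives a number 2.3 percentage points lower from compound 3 to compound 4 (within the scatter), the first one-place comparison available in the series. At this position, then, the hydroxymethyl arm can go without a step that can be told from the scatter, though neither compound shows inhibition. No separate measurement bears on this result. From the compounds shown here alone, with both numbers negative, the effect of this change on a compound that does inhibit stays open. Also open, going by these compounds, is whether an amine or a carboxylic acid on this carbon would move the number beyond the scatter.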